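Cyclobutyl to propylsulfanyl in the acylguanidine series

The source may report more compounds than this note shows. Statements on the series, on what has been measured and on what is new or still open speak of the compounds shown alone.

Measured in a functional assay for inhibition of sodium/hydrogen exchanger (Oryctolagus cuniculus) (a lower number here means a stronger inhibitor, a higher number a weaker inhibitor), so far:
compound 1 `CCc1cc(Br)c(S(C)(=O)=O)cc1C(=O)N=C(N)N` gives 41 nM
compound 2 `Cc1c(C(=O)N=C(N)N)cc(S(C)(=O)=O)c(Cl)c1C` gives 58 nM
compound 3 `Cc1cc(C2CCC2)c(S(C)(=O)=O)cc1C(=O)N=C(N)N` gives 8.2 nM

Compound 3 has the lowest number of the three. Its nearest neighbour is compound 1, whose number is higher by a gap beyond the scatter; compound 2 lies further off, also beyond the scatter. On these values compound 3 is the strongest inhibitor measured. Among the measured compounds shown here, no pair of the three differs in a single place, so no single change has been isolated yet.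

Compound 4 `CCCSc1cc(C)c(C(=O)N=C(N)N)cc1S(C)(=O)=O` is the next compound, not yet measured in this assay. It differs from compound 3 in one place: propylsulfanyl in place of cyclobutyl on an aromatic carbon. A four-membered ring of carbon only gives way to a chain of the same heavy-atom count that carries a sulfur and one hydrogen-bond acceptor.

For the measured compounds named here, no measured step covers a ring-to-chain change at this position, so the expectation rests on compound 3 alone. The step is expected to be small, toward a higher number, and may well fall within the scatter: a 1.8-fold higher number from compound 3 to compound 4 (0.26 log units; within the scatter). For compound 4 the estimate in this assay is 15 nM, with a range from 5 nM to 45 nM.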

Compound 4, half-maximal inhibitory concentration: 6.8 nM
Beside the measured number, compound 4's estimate is 2.2-fold (0.34 log units) above it; measured number inside the range.
By their numbers in this assay, from the lowest: compounds 4 and 3 (each within the scatter of the next); then compounds 1 and 2 (each within the scatter of the next).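

In this assay, the one-place change at this aromatic carbon, ortho to a methylsulfonyl group, gives a 1.2-fold lower number from compound 3 to compound 4 (0.08 log units; within the scatter), so compound 3 and compound 4 cannot be told apart. The four-membered carbon ring is therefore not required for activity at this position in this pair: an open propylsulfanyl chain of the same heavy-atom count, carrying a sulfur and one hydrogen-bond acceptor, stands level with it. Nothing available explains why the two groups read alike.

Among the compounds shown here, the single step removes the ring and brings in the sulfur together, so the contribution of each stays unresolved. A butyl chain would help to separate them, as would a propoxy group, and a longer chain such as pentylsulfanyl or an amine at this position would test how far the tolerance extends.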